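The source may hold more compounds than are shown below. What is called first, only, known or untested is meant among the compounds shown, and "the series" means these compounds.

Three compounds share one core and differ only in the aryl group attached to an aromatic nitrogen. Compound 1, `CC(C)(C)OC(=O)N1CC=C(c2cn(-c3cccc(F)c3)nn2)CC1`, carries a 3-fluorophenyl there and in a functional assay on CHO cells for antagonist activity at metabotropic glutamate receptor 5 (Homo sapiens), read by FLIPR and calcium flux (on this read-out lower numbers stand for stronger inhibition and higher numbers for weaker inhibition), compound 1 gives 1100 nM. Compound 2, `Cc1ccccc1-n1cc(C2=CCN(C(=O)OC(C)(C)C)CC2)nn1`, carries a 2-methylphenyl instead, and in this assay compound 2 gives 880 nM; the change gives a 1.3-fold lower number from compound 1 to compound 2 (0.10 log units; within the scatter). Compound 3, `CC(C)(C)OC(=O)N1CC=C(c2cn(-c3ccccn3)nn2)CC1`, carries a pyridin-2-yl and in this assay compound 3 gives 8700 nM, the highest of the three numbers: the moves to it are a 7.9-fold higher number from compound 1 to compound 3 (0.90 log units; beyond the scatter) and a 9.9-fold higher number from compound 2 to compound 3 (1.00 log units; beyond the scatter).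

Compound 4, `CC(C)(C)OC(=O)N1CC=C(c2cn(-c3ccncc3)nn2)CC1`, differs from compound 3 only in the change (pyridin-4-yl in place of pyridin-2-yl on an aromatic nitrogen), so the ring nitrogen changes its position while everything else stays the same. Going by the values given here, no measured step tests a shift of a nitrogen within the pyridine; the two steps that bear on it only show that a pyridine ring in this place sits above the two phenyls. The number for compound 4 is therefore expected to stay in the region of compound 3, with a possible modest move toward the phenyls, giving the expected step of a 1.7-fold lower number from compound 3 to compound 4 (0.24 log units; within the scatter). Compound 4 is estimated at 5000 nM, within a range from 1500 nM to 16000 nM.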

Compound 4, half-maximal inhibitory concentration: > 10000 nM
Compound 4 ended at the assay's limit; the forecaster's own chance of this, stated with the estimate: 10%; middle value at least 2.0-fold (0.30 log units) away from the limit.
By their numbers in this assay, from the lowest: compounds 2 and 1 (each within the scatter of the next); then compound 3. At a limit, above all of these: compound 4.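

Compound 4 gives no number in this assay, only a limit: the limit of > 10000 nM in this assay, at which 1 of the 4 values shown sits.

Even so, the limit is enough for comparison with the two phenyl compounds, with an at least 11-fold higher number from compound 2 to compound 4 (1.05 log units; beyond the scatter) and an at least 9.0-fold higher number from compound 1 to compound 4 (0.95 log units; beyond the scatter), so the weaker inhibition seen with pyridin-2-yl in compound 3 is also seen with a second pyridine, pyridin-4-yl. Against compound 3 itself, the comparison gives only an at least 1.1-fold higher number from compound 3 to compound 4 (0.06 log units; that floor lies within the scatter), so these data do not show whether moving the ring nitrogen changes inhibition at all.

Still open, as far as these compounds go, is whether pyridin-3-yl, the remaining pyridine attachment, would fall with these two pyridines or nearer the phenyls, and whether a phenyl ring carrying an amine or a carboxylic acid would stay close to compound 1 and compound 2. Also open, from the compounds shown here alone, is whether any group at this place on the triazole-like five-membered ring can give much stronger inhibition than these two phenyl compounds do.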